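The source may report more compounds than this note shows. Statements on the series, on what has been measured and on what is new or still open speak of the compounds shown alone.

Measured compounds in a functional assay on MGC-803 cells (Homo sapiens) for inhibition, read by MTT assay, with a stated time of 72 h; a higher number here means a weaker inhibitor, a lower number a stronger inhibitor:
compound 1, `Cc1cc(Nc2cc(-c3ccccc3)[nH]n2)n2nc(SCCc3ccccc3)nc2n1`: 5620 nM
compound 2, `Cc1ccc(Cn2ccc(Nc3cc(C)nc4nc(SCc5ccc(Br)cc5)nn34)n2)cc1`: 7420 nM
compound 3, `CCCSc1nc2nc(C)cc(Nc3cc(-c4ccccc4)[nH]n3)n2n1`: 12600 nM

Compound 2 stands with the others: its number and that of compound 1 differ by less than the usual scatter, and the same holds for compound 2 against compound 3, so the three cannot be ranked on these data alone. For the measured compounds named here, the only step between measured compounds is a 2.2-fold higher number from compound 1 to compound 3 (0.35 log units; beyond the scatter), a change on the chain attached to the sulfur.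

Compound 4, `Cc1cc(Nc2ccn(Cc3ccccc3)n2)n2nc(SCc3ccc(Br)cc3)nc2n1`, differs from compound 2 in one place: hydrogen in place of methyl on an aromatic carbon. Going by the values given here, no measured step touches this ring or this kind of change; the step from compound 1 to compound 3 concerns a different part of the molecule and does not bear on it directly. Removal of a single methyl from an aromatic carbon is a small change, and without a relevant precedent the expectation is a step of no more than the scatter, in either direction. Compound 4 is therefore estimated at 7500 nM in this assay, with a range of 3000 nM to 19000 nM, which corresponds to an expected 1.0-fold higher number from compound 2 to compound 4 (0.00 log units; within the scatter).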

Compound 4, half-maximal inhibitory concentration: 4720 nM
Compound 4: the middle estimate sits 1.6-fold (0.20 log units) above what was measured; low and high end bracket the measured number.
By their numbers in this assay, from the lowest: compounds 4, 1, 2 and 3 (each within the scatter of the next, the first and the last beyond it).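

In this assay, for the compounds shown here, going from 4-methylbenzyl to benzyl gives a 1.6-fold lower number from compound 2 to compound 4 (0.20 log units; within the scatter), the first reading at this position, which no step among the earlier compounds touched. On these data, the methyl on this six-membered aromatic ring can be left off without a difference that exceeds the scatter, so compound 2 and compound 4 cannot be ranked. No supporting measurement bears on this result.

Still open, from the compounds shown here alone, is whether a methoxy group, an amine or a carboxylic acid at this ring position would give a step beyond the scatter. Also open, going by these compounds, is whether the change from 4-methylbenzyl to benzyl reads the same when the chain on the sulfur is the propyl chain of compound 3 rather than the bromobenzyl group of compound 4.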